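This account rests on a few compounds, and the source may have more. Where it says the series, first, only, none or still open, it means among the compounds named here.

Measured compounds:
compound 1, `N[C@H]1CC[C@H](Nc2c(C(=O)NCc3ccccn3)nc(Br)c3cccnc23)CC1`, "not determined" (no result reported) in a functional assay on HCT-116 cells (Homo sapiens) for cytotoxicity, read by MTT assay, with a stated time of 72 h; a lower number here means a stronger inhibitor, a higher number a weaker inhibitor
compound 2, `N[C@H]1CC[C@H](NC(=O)c2nc(Br)c3cccnc3c2NCc2ccc(F)cc2)CC1`, 6400 nM

Compound 1 has no number of its own in this assay, its entry being "not determined" (no result reported); the only figure in the series comes from compound 2, which gives 6400 nM in this assay. Compound 2 shares the amide and the diaminocyclohexane part with compound 1 but places the two side chains differently, so its value is only a loose reference for the present step rather than a direct anchor.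

Compound 3, `N[C@H]1CC[C@H](Nc2c(C(=O)NC3CCCCC3)nc(Br)c3cccnc23)CC1`, is the compound to be measured. It differs from compound 1 by cyclohexyl in place of (pyridin-2-yl)methyl on an amide-type nitrogen. Going by the values given here, nothing shows what this exchange does: no pair of measured compounds isolates it, and compound 1 itself is unmeasured. The expected size of the step is therefore unknown; the working assumption is a change of no more than moderate size in either direction, with the value likely to land in the same weak region as compound 2.

Compound 3 is estimated at 6000 nM in this assay, with a range from 1200 nM to 30000 nM.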

Compound 3, half-maximal inhibitory concentration: > 10000 nM
Compound 3 was reported as a limit; the forecaster's own chance of this, stated with the estimate: 20%; middle value at least 1.6-fold (0.22 log units) away from the limit.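

No new step can be read between compound 1 and compound 3. In this assay, compound 3 gives > 10000 nM, which is a limit of the assay and not a number. The compounds shown leave open how far cyclohexyl in place of (pyridin-2-yl)methyl on an amide-type nitrogen shifts the value in this assay, or in which direction.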